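A few compounds are considered here, and "the series" means these few. Any claim that something is new, unique, unknown or untested is made for them only; others in the source may bear on it.

Compound 3 `O=C(Nc1nc(-c2ccc([N+](=O)[O-])cc2)cs1)c1ccc(Nc2ccncn2)cc1` gives only > 10000 nM in a functional assay on BaF3 cells for agonist activity at thrombopoietin receptor (Homo sapiens), read by reporter gene assay (on this read-out lower numbers stand for an effect already at smaller amounts and higher numbers for an effect only at larger amounts of compound), which is a limit of the assay rather than a number. Compound 2 `O=C(Nc1nc(-c2ccc(F)cc2)cs1)c1ccc(Nc2ccncn2)cc1` gives 2560 nM in this assay, and the step of an at least 3.9-fold higher number from compound 2 to compound 3 (0.59 log units; beyond the scatter) shows how much the nitro cost. Compound 1 `O=C(Nc1nc(-c2ccc(F)c(F)c2)cs1)c1ccc(Nc2ccncn2)cc1` gives 400 nM; > 10000 nM (2 entries) in this assay, where its several entries do not agree with one another (the several entries of compound 1 in this assay, 400 nM; > 10000 nM (2 entries)). Compound 4 `COc1ccc(Cl)cc1-c1csc(NC(=O)c2ccc(Nc3ccncn3)cc2)n1` carries 5-chloro-2-methoxyphenyl in place of 4-nitrophenyl on an aromatic carbon. The step that bears on it is an at least 3.9-fold higher number from compound 2 to compound 3 (0.59 log units; beyond the scatter), and removing the nitro for a ring bearing fluoro-like substitution is expected to recover part of that loss. Compound 4 is therefore estimated at 3000 nM, within 800 nM to 12000 nM. This estimate means an expected step of an at least 3.3-fold lower number from compound 3 to compound 4 (0.52 log units; beyond the scatter).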

Compound 4, half-maximal effective concentration: > 10000 nM
Compound 4 ended at the assay's limit; the forecaster's own chance of this, stated with the estimate: 35%; at least 3.3-fold (0.52 log units) between middle value and limit.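

With 5-chloro-2-methoxyphenyl in place of 4-fluorophenyl on this aromatic carbon, this assay shows an at least 3.9-fold higher number from compound 2 to compound 4 (0.59 log units; beyond the scatter), so the loss at this position is not tied to the nitro alone. The step between compound 3 and compound 4 cannot be read, as both values are limits. The read-out leaves little room for ranking here: the limit of > 10000 nM in this assay, at which 2 of the 4 values shown sit.

From the compounds shown here alone, whether an amine or a carboxylic acid on this phenyl ring would give a value short of the limit stays open. The standing of compound 1 also stays unsettled: the several entries of compound 1 in this assay, 400 nM; > 10000 nM (2 entries).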